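Swapping the amide substituent on a shared oxime core

A few compounds are considered here, and "the series" means these few. Any claim that something is new, unique, unknown or untested is made for them only; others in the source may bear on it.

Three compounds share a core that carries an amidoxime on one side and, in two of them, a thioethyl amide chain on the other. In an assay for inhibition of Indoleamine 2,3-dioxygenase 1 (Homo sapiens), read by fluorescence, with a stated time of 24 h (a lower number here means a stronger inhibitor, a higher number a weaker inhibitor), compound 1 `NS(=O)(=O)CC(=O)NCCSc1nonc1/C(=N/O)Nc1cccc(C(F)F)c1` gives 17 nM, compound 2 `CC1(C(=O)NCCSc2nonc2/C(=N/O)Nc2ccc(F)c(C(F)F)c2)CCN1` gives 16 nM, and compound 3 `COc1nonc1/C(=N/O)Nc1ccc(F)c(Br)c1` gives 39 nM. Compound 2 thus gives the lowest number of the three, though its gap to compound 1 lies within the scatter, while its gap to compound 3 lies beyond it.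

Compound 4 `N#CCC(=O)NCCSc1nonc1/C(=N/O)Nc1ccc(F)c(C(F)F)c1` differs from compound 2 in the group attached to the amide carbonyl: a group of 3 heavy atoms (2 carbon, 1 nitrogen; no ring) in place of a group of 5 heavy atoms (4 carbon, 1 nitrogen; one four-membered non-aromatic ring with 1 hetero atom), on a carbonyl carbon. Among the measured compounds shown here, no measured pair shows the effect of such a change on this carbonyl directly. Compound 1 and compound 2 carry quite different groups at this position yet give numbers within the scatter of each other, which suggests that this part of the molecule is tolerant of variation. Compound 4 is therefore expected to stay close to compound 2, with a step from compound 2 to compound 4 of a 1.6-fold higher number from compound 2 to compound 4 (0.19 log units; within the scatter) in this assay. For compound 4 the estimate is 25 nM, expected to fall between 10 nM and 65 nM.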

Compound 4, half-maximal inhibitory concentration: 6.5 nM
For compound 4 the middle estimate is 3.8-fold (0.59 log units) above the measured one, and the stated range ends above it.
By their numbers in this assay, from the lowest: compound 4; then compounds 2 and 1 (each within the scatter of the next); then compound 3.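

Exchanging the group on this carbonyl, with cyanomethyl entering for the four-membered ring group, brings a 2.5-fold lower number from compound 2 to compound 4 (0.39 log units; beyond the scatter) in this assay. Among the compounds shown here, this single-place pair shows that the position is not simply tolerant, as the earlier compounds suggested: the group on the carbonyl can move the number beyond the scatter. The data give no account of why the number falls with this exchange.

From the compounds shown here alone, whether the step belongs to the nitrile itself or to the loss of the ring remains open, since this one pair changes both together. Nor do the compounds shown tell how a simple methyl group, a carboxylic acid or a longer chain ending in a nitrile would behave on this carbonyl, so how far the trend extends cannot be said.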